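The compounds below may be only part of what the source reports. "The series", "measured", "known", "first", "only" and "open" are said of these compounds alone.

Compound 1 `O=C(Nc1ccc(Cl)cc1)c1c(O)c2cccnc2n(-c2ccccc2)c1=O`: 2.5%
Compound 2 `Cc1cccc(NC(=O)c2c(O)c3cccnc3n(-c3ccccc3)c2=O)c1`: 4.5%

In a functional assay on the whole organism for inhibition, with Rattus norvegicus as the target, read by cytopathic effect and paw edema, at a dose of 100 mg/kg by the oral route (a lower number here means less inhibition, a higher number more inhibition at the dose given (going by the name of the read-out)), compound 1 gives 2.5%, and compound 2 gives 4.5%. Going by the values given here, compound 2 holds the higher of the two numbers, yet the one measured step, a number 2 percentage points higher from compound 1 to compound 2 (within the scatter), stays within the scatter, so the two compounds cannot be told apart on these data. Both numbers are low: neither compound inhibits to any marked degree at this dose.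

Compound 3 `O=C(Nc1cccc(Cl)c1)c1c(O)c2cccnc2n(-c2ccccc2)c1=O` differs from compound 2 by chloro in place of methyl on an aromatic carbon. Among the compounds with values here, the single step that bears on this change is the one that also swapped the group on the amide-type nitrogen, a number 2 percentage points higher from compound 1 to compound 2 (within the scatter), and that step did not leave the scatter. Within the data shown here, with only that step to go on, the exchange of methyl for chloro on the same ring is expected to move the number little, if at all. The step this estimate means, a number 0.5 percentage points lower from compound 2 to compound 3 (within the scatter), is expected to fall within the scatter. For compound 3 the expected value in this assay is 4%, with a range from 0% to 14%.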

Compound 3, a percentage reported as inhibition, in the whole organism at one dose (the size of the read-out at that dose, not a potency): 13.4%
Beside the measured number, compound 3's estimate is 9.4 percentage points below it; the range from low to high includes it.
By their numbers in this assay, from the lowest: compounds 1, 2 and 3 (each within the scatter of the next, the first and the last beyond it).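

In this assay, going by these compounds alone, moving the chlorine around the ring on the amide-type nitrogen produces the only step so far that leaves the scatter: 3-chlorophenyl in place of 4-chlorophenyl gives a number 10.9 percentage points higher from compound 1 to compound 3 (beyond the scatter) and counts as modest, so the place of the chloro on this ring can matter, even though the numbers remain low overall. Chloro in place of methyl on the same aromatic carbon gives a number 8.9 percentage points higher from compound 2 to compound 3 (within the scatter) and stays inside the scatter, so these data cannot tell the two groups apart at this position, and compound 3 stands clear of compound 1 alone. No measurement on hand accounts for either step.

The compounds shown leave open whether a quite different group in that same place, such as methoxy, an amine or a carboxylic acid, would give a clearly larger number at this dose. They also leave open whether 4-methylphenyl would stand to 3-methylphenyl as 4-chlorophenyl stands to 3-chlorophenyl, which would show whether the effect of place holds beyond the chloro pair.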